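Swapping the aryl cap on the triazole of a urea series

This account rests on a few compounds, and the source may have more. Where it says the series, first, only, none or still open, it means among the compounds named here.

Measured so far:
- compound 1, `COc1ccc(-n2cc(COc3cccc(NC(=O)Nc4ccc(Cl)c(C(F)(F)F)c4)c3)nn2)cc1`: 4680 nM
- compound 2, `Cc1cccc(-n2cc(COc3cccc(NC(=O)Nc4ccc(Cl)c(C(F)(F)F)c4)c3)nn2)c1`: 7270 nM
- compound 3, `CC(C)c1cccc(-n2cc(COc3cccc(NC(=O)Nc4ccc(Cl)c(C(F)(F)F)c4)c3)nn2)c1`: 3250 nM

All three share one core and differ only in the aromatic group attached to the ring nitrogen of the triazole. In a functional assay on HepG2 cells (Homo sapiens) for inhibition, read by MTT assay, with a stated time of 72 h (on this read-out lower numbers stand for stronger inhibition and higher numbers for weaker inhibition), compound 3 shows the lowest number of the three, but its separation from compound 1 is small: the step of a 1.4-fold lower number from compound 1 to compound 3 (0.16 log units; within the scatter) stays within the scatter, so the two cannot be ranked. Only against compound 2 does compound 3 stand apart, through the step of a 2.2-fold lower number from compound 2 to compound 3 (0.35 log units; beyond the scatter), a modest gain. The step of a 1.6-fold higher number from compound 1 to compound 2 (0.19 log units; within the scatter) is likewise within the scatter.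

Compound 4, `O=C(Nc1cccc(OCc2cn(-c3ccc(F)cc3)nn2)c1)Nc1ccc(Cl)c(C(F)(F)F)c1`, carries the change (4-fluorophenyl in place of 3-isopropylphenyl on an aromatic nitrogen). The group that enters is smaller than the one that leaves, and among the measured compounds the closest analogue is compound 1, whose 4-methoxyphenyl also sits at the same ring nitrogen. The steps from compound 1 and from compound 2 to compound 3 were small or modest, so a small shift toward a higher number is the most that is expected here. Compound 4 is therefore estimated at 4800 nM in this assay, with a range from 2400 nM to 9600 nM, which amounts to an expected step of a 1.5-fold higher number from compound 3 to compound 4 (0.17 log units; within the scatter).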

Compound 4, half-maximal inhibitory concentration: 1350 nM
The estimate for compound 4 lay 3.6-fold (0.55 log units) above the measured number; measured number below the stated range.
By their numbers in this assay, from the lowest: compound 4; then compounds 3, 1 and 2 (each within the scatter of the next, the first and the last beyond it).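

In this assay this position proves more responsive to the aryl cap than the first three compounds suggested, since 4-fluorophenyl on the triazole nitrogen gives a drop beyond the scatter against every earlier cap: a 2.4-fold lower number from compound 3 to compound 4 (0.38 log units; beyond the scatter) and a 5.4-fold lower number from compound 2 to compound 4 (0.73 log units; beyond the scatter) and a 3.5-fold lower number from compound 1 to compound 4 (0.54 log units; beyond the scatter) in the pair that differs least, with only fluoro in place of methoxy on an aromatic carbon. That last pair shows that the group on the aryl ring can matter even when the ring itself stays the same, and compound 4 now stands as the most potent of the four in this assay. Nothing given here accounts for this gain, so its cause remains unknown.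

These four compounds cannot show whether the gain is specific to fluoro, and a chloro or a nitrile in place of the fluoro, or a plain phenyl cap, would help to settle that. They also leave open how a fluoro elsewhere on the ring would compare, and whether the same cap would still give a lower number if the trifluoromethyl on the far side of the urea were replaced by a methyl.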